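The source may hold more compounds than are shown below. What is called first, only, known or untested is meant among the compounds shown, and "the series" means these compounds.

Measured compounds in a functional assay on the whole organism (strain Swiss albino) with Mus musculus as the target, with stated times of 30 min and 10 min, at a dose of 50 mg/kg by the oral route; on this read-out higher numbers stand for more inhibition at the one dose given (going by the name of the read-out) and lower numbers for less inhibition:

Compound 1, `CC(=O)c1c(NNc2ccc(Br)cc2)cc(C)oc1=O`, gives 53.1%.
Compound 2, `COc1ccc(NNc2cc(C)oc(=O)c2C(C)=O)cc1`, gives 59.2%.
Compound 3, `Cc1cc2nn(-c3ccc(Br)cc3)c(C)c2c(=O)o1`, gives 44.9%.

Compound 1 and compound 2 share one core and differ in one place: methoxy in place of bromo on an aromatic carbon. This change gave a number 6.1 percentage points higher from compound 1 to compound 2 (within the scatter), so the two numbers cannot be told apart with confidence. Compound 3 sits on a different core; how the two cores differ is not broken down here. Its value in this assay lies within the scatter of compound 1, while compound 2 reads higher than compound 3 by more than the scatter.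

Compound 4, `COc1ccc(-n2nc3cc(C)oc(=O)c3c2C)cc1`, has not yet been measured. It stands to compound 3 as compound 2 stands to compound 1: methoxy in place of bromo on an aromatic carbon. The place is described in the same words for both pairs, so this is the same change made on a second core. Within the data shown here, the only guide to its effect is the single measured pair, where the step from compound 1 to compound 2 was within the scatter. On that basis a step of similar size is expected, a number 6.1 percentage points higher from compound 3 to compound 4 (within the scatter), which would leave compound 4 close to compound 3. Given the value of compound 3, 44.9%, compound 4 is estimated at 51%, with a plausible range from 38% to 64%; a second core may not echo the first pair, so the range is kept wide.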

Compound 4, a percentage reported as inhibition, in the whole organism at one dose (the size of the read-out at that dose, not a potency): 75.9%
Compound 4: middle estimate off by 24.9 percentage points, on the low side; measured number above the stated range.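

In this assay, methoxy in place of bromo on the aromatic carbon gave a number 31 percentage points higher from compound 3 to compound 4 (beyond the scatter), so the change did not carry over at the same size from one core to the other: the same change on two cores in this assay, a number 6.1 percentage points higher (within the scatter) from compound 1 to compound 2 and a number 31 percentage points higher (beyond the scatter) from compound 3 to compound 4, 24.9 percentage points apart, beyond the scatter of two such steps

Only on the core of compound 3 does this change stand clear of the scatter, while on the core of compound 1 the two numbers cannot be told apart. With a single pair on each core, this shows that the size of the step depends on the core for these four compounds only; it does not show what in the cores sets the gap, whether a third core would follow either pair, or whether the same gap would appear at another dose.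

The compounds shown hold only bromo and methoxy at this place, para to a large group, so it remains open how an amine, a hydroxy group or a carboxylic acid would read there on either core. As far as these compounds go, it also remains open whether an ethoxy group or a longer alkoxy chain would keep the large step seen on the core of compound 3.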